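The compounds below may be only part of what the source reports. "The series", "measured", "known", "first", "only" and "open" are said of these compounds alone.

Measured compounds:
compound 1 `COc1ccc(N(C)c2nc(C)nc3ccccc23)cc1OCCC[Se]C#N` — 921 nM
compound 2 `COc1ccc(N(C)c2nc(C)nc3ccccc23)cc1C(=O)NCC[Se]C#N` — 561 nM
compound 3 `COc1ccc(N(C)c2nc(C)nc3ccccc23)cc1OCC[Se]C#N` — 19 nM

In a functional assay on LoVo cells (Homo sapiens) for inhibition, read by MTT assay, with a stated time of 48 h (a lower number here means a stronger inhibitor, a higher number a weaker inhibitor), compound 1 gives the highest of the three numbers. Compound 2 sits nearest, with a 1.6-fold lower number from compound 1 to compound 2 (0.22 log units; within the scatter), whereas compound 3 lies farthest, with a 48-fold lower number from compound 1 to compound 3 (1.69 log units; beyond the scatter); compound 2 to compound 3 shows a 30-fold lower number from compound 2 to compound 3 (1.47 log units; beyond the scatter).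

Compound 4 `COc1ccc(N(C)c2nc(C)nc3ccccc23)cc1C[Se]C#N` is not yet measured. It differs from compound 1 as follows: a group of 4 heavy atoms (2 carbon, 1 nitrogen, 1 selenium; no ring) in place of a group of 7 heavy atoms (4 carbon, 1 nitrogen, 1 oxygen, 1 selenium; no ring), on an aromatic carbon. Among the measured compounds shown here, the step that bears most directly on this change is the one from compound 1 to compound 3, where taking one carbon out of the chain on the same aromatic carbon gave a large drop in the number. For the measured compounds named here, compound 4 goes further in that direction and also loses the oxygen of the chain, so no measured step matches it exactly. A lower number than compound 1 is expected, though not with the confidence the step to compound 3 would suggest on its own. Compound 4 is expected to give 150 nM, with a range from 20 nM to 1000 nM, which would mean an estimated 6.1-fold lower number from compound 1 to compound 4 (0.79 log units; beyond the scatter).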

Compound 4, half-maximal inhibitory concentration: 277 nM
Estimate against measurement, compound 4: 1.8-fold (0.27 log units) below; low and high end bracket the measured number.
By their numbers in this assay, from the lowest: compound 3; then compound 4; then compounds 2 and 1 (each within the scatter of the next).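

At this aromatic carbon, in this assay, the group of 4 heavy atoms in place of the group of 7 heavy atoms gives a 3.3-fold lower number from compound 1 to compound 4 (0.52 log units; beyond the scatter), and the amide of compound 2 also gives way to it, with a 2.0-fold lower number from compound 2 to compound 4 (0.31 log units; beyond the scatter). Against compound 3, however, the shortest group loses much of the gain, with a 15-fold higher number from compound 3 to compound 4 (1.16 log units; beyond the scatter), so the number does not simply fall as the group shortens: compound 3 gives the lowest number, and compound 4 goes against any such trend. No measurement shown here explains this difference.

The compounds shown leave open whether the ether oxygen of compound 3 or the chain length matters more, since none carries an all-carbon chain or an amine at that place. They also leave open how sulfur in place of selenium would read.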